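Swapping the Aryl Group on the Shared Core

The source may hold more compounds than are shown below. What is called first, only, known or untested is meant among the compounds shown, and "the series" means these compounds.

Compound 1, `COc1cc(NC(=O)Nc2cc(Nc3ccc(OC)c(C)c3)ncn2)cc(OC)c1`: 39.7%
Compound 2, `COc1cc(Br)ccc1Nc1cc(NC(=O)Nc2c(Cl)cccc2Cl)ncn1`: 43%
Compound 3, `COc1ccc(C(F)(F)F)cc1Nc1cc(NC(=O)Nc2c(Cl)cccc2Cl)ncn1`: 60.1%

All three measured compounds share a core and were tested in a functional assay on NCI-H226 cells (Homo sapiens) for inhibition, read by MTT assay, with a stated time of 48 h, tested at 10 uM; a higher number here means more inhibition at the concentration tested (going by the name of the read-out), a lower number less inhibition. Compound 1 stands lowest of the three numbers. Compound 2 lies within the scatter of compound 1, so the two cannot be ranked, while compound 3 sits beyond the scatter above compound 1. Compounds 2 and 3 each differ from compound 1 in more than one place, so no single structural step can be read from them.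

Compound 4, `COc1cc(NC(=O)Nc2cc(Nc3ccc(C(C)(C)C)cc3)ncn2)cc(OC)c1`, differs from compound 1 in one place: 4-(tert-butyl)phenyl in place of 4-methoxy-3-methylphenyl on a nitrogen on an aromatic ring. Among the measured compounds shown here, no measured pair isolates this change, so only a modest step is expected in this assay, possibly none beyond the scatter. Compound 4 is estimated at 45%, within 25% to 65%. The expected step is then a number 5.3 percentage points higher from compound 1 to compound 4 (within the scatter).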

Compound 4, a percentage reported as inhibition, at one concentration (the size of the read-out at that concentration, not a potency): 47.7%
Compound 4: middle estimate off by 2.7 percentage points, on the low side; low and high end bracket the measured number.
By their numbers in this assay, from the lowest: compounds 1, 2 and 4 (each within the scatter of the next); then compound 3.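

In this assay, among the compounds shown here, exchanging 4-methoxy-3-methylphenyl for the all-carbon 4-(tert-butyl)phenyl on this nitrogen gives a number 8 percentage points higher from compound 1 to compound 4 (within the scatter) and so offers the first single-place comparison on the shared core. For this pair, the methoxy oxygen is not required to keep the read-out at this level. No measured evidence accounts for this result. On these data alone, whether an aryl group carrying an amine or a carboxylic acid would shift the number remains open. So does whether the same exchange would behave alike in compound 3.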